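This account rests on a few compounds, and the source may have more. Where it says the series, first, only, none or still open, it means among the compounds named here.

In a functional assay on A549 cells (Homo sapiens) for antiproliferative activity, read by MTT assay, with a stated time of 48 h (on this read-out higher numbers stand for weaker inhibition of growth and lower numbers for stronger inhibition of growth), compound 3 (`COC(=O)N1N=C(c2cccc(C)c2)CC1c1cc(OC)c(OC)c(OC)c1`) gives 300 nM, the lowest of the three numbers, against 3400 nM for compound 1 (`COC(=O)N1N=C(c2ccc(OC)cc2)CC1c1cc(OC)c(OC)c(OC)c1`) and 3170 nM for compound 2 (`COC(=O)N1N=C(c2cccc(O)c2)CC1c1cc(OC)c(OC)c(OC)c1`). Compound 4 (`COC(=O)N1N=C(c2ccc(OC)c(OC)c2)CC1c1cc(OC)c(OC)c(OC)c1`) keeps the shared core but has 3,4-dimethoxyphenyl in place of 3-methylphenyl on a carbon with a double bond to nitrogen. For the measured compounds named here, three measured steps bear on this. Putting 3-methylphenyl in place of 4-methoxyphenyl gave an 11-fold lower number from compound 1 to compound 3 (1.05 log units; beyond the scatter), and methyl in place of hydroxy gave an 11-fold lower number from compound 2 to compound 3 (1.02 log units; beyond the scatter), both large, whereas a 1.1-fold lower number from compound 1 to compound 2 (0.03 log units; within the scatter) stays within the scatter. Compound 4 lacks the methyl group and carries methoxy groups, so a large move back towards higher numbers is expected. The expected change is a 6.0-fold higher number from compound 3 to compound 4 (0.78 log units; beyond the scatter). For compound 4, the estimated value is 1800 nM, within an expected range of 500 nM to 5000 nM.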

Compound 4, concentration for 50% growth inhibition: 3930 nM
Compound 4: the middle estimate sits 2.2-fold (0.34 log units) below what was measured, within the range that was stated.
By their numbers in this assay, from the lowest: compound 3; then compounds 2, 1 and 4 (each within the scatter of the next).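

In this assay the low number proves specific to 3-methylphenyl on the carbon with a double bond to nitrogen, since 3,4-dimethoxyphenyl there gives a 13-fold higher number from compound 3 to compound 4 (1.12 log units; beyond the scatter) and does not retain it. Methoxy in place of hydrogen on an aromatic carbon adds nothing beyond the scatter, giving a 1.2-fold higher number from compound 1 to compound 4 (0.06 log units; within the scatter) and, against the hydroxy compound, a 1.2-fold higher number from compound 2 to compound 4 (0.09 log units; within the scatter) so that these three aryl groups cannot be ranked. No evidence offered here accounts for why the methyl compound stands apart.

As far as these compounds go, whether 4-methylphenyl, 3-ethylphenyl or 3-chlorophenyl would keep the low number remains open. So does the effect of an amine in place of that methyl.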